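Methyl in Place of 4-Fluorophenyl on the Shared Core

The source may hold more compounds than are shown below. What is called first, only, known or untested is meant among the compounds shown, and "the series" means these compounds.

Of the compounds shown here, three on a shared core have been measured in a functional assay on HepG2 cells (Homo sapiens) for inhibition, read by MTT assay, with a stated time of 72 h; a lower number here means a stronger inhibitor, a higher number a weaker inhibitor. Compound 1 `Cc1ccc(-c2cc(C(=O)N3CCC4(CC3)CC(=O)c3nn(C(C)(C)C)cc3O4)c3ccccc3n2)cc1` gives 1440 nM, compound 2 `CC(C)(C)n1cc2c(n1)C(=O)CC1(CCN(C(=O)c3cc(-c4ccc(F)cc4)nc4ccccc34)CC1)O2` gives 2930 nM, and compound 3 `CC(C)(C)n1cc2c(n1)C(=O)CC1(CCN(C(=O)c3cc(N4CCNCC4)nc4ccccc34)CC1)O2` gives 8570 nM. Compound 2 thus stands second highest of the three, with a 2.0-fold higher number from compound 1 to compound 2 (0.31 log units; beyond the scatter) and a 2.9-fold higher number from compound 2 to compound 3 (0.47 log units; beyond the scatter). Compound 4 `Cc1cc(C(=O)N2CCC3(CC2)CC(=O)c2nn(C(C)(C)C)cc2O3)c2ccccc2n1` differs from compound 2 by methyl in place of 4-fluorophenyl on an aromatic carbon. The step that bears most on this change is a 2.9-fold higher number from compound 2 to compound 3 (0.47 log units; beyond the scatter), where the 4-fluorophenyl also left; a 2.0-fold higher number from compound 1 to compound 2 (0.31 log units; beyond the scatter) is smaller, and a 6.0-fold higher number from compound 1 to compound 3 (0.77 log units; beyond the scatter) spans both changes. Compound 4 is expected to show a step of a 2.4-fold higher number from compound 2 to compound 4 (0.38 log units; beyond the scatter), because the number rose in a 2.9-fold higher number from compound 2 to compound 3 (0.47 log units; beyond the scatter) when the 4-fluorophenyl left. Compound 4 is therefore estimated at 7000 nM, within 2500 nM to 20000 nM.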

Compound 4, half-maximal inhibitory concentration: 9480 nM
Compound 4: the middle estimate sits 1.4-fold (0.13 log units) below what was measured, within the range that was stated.
By their numbers in this assay, from the lowest: compound 1; then compound 2; then compounds 3 and 4 (each within the scatter of the next).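

At this position, on an aromatic carbon next to the ring nitrogen, methyl gives a clearly higher number than either aryl group, 4-fluorophenyl (a 3.2-fold higher number from compound 2 to compound 4 (0.51 log units; beyond the scatter)) or 4-methylphenyl (a 6.6-fold higher number from compound 1 to compound 4 (0.82 log units; beyond the scatter)). Methyl and piperazin-1-yl are not separated (a 1.1-fold higher number from compound 3 to compound 4 (0.04 log units; within the scatter)), so among these four compounds only the two carrying an aromatic ring here give the lower numbers. Nothing given here accounts for these steps. Going by these compounds, whether a benzyl group, a longer alkyl chain or a pyridine ring at this position would behave like the aryl groups or like methyl stays open.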